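Notes on the aryl swap from compound 2 to compound 3

This account rests on a few compounds, and the source may have more. Where it says the series, first, only, none or still open, it means among the compounds named here.

Measured so far in a functional assay on A549 cells (Homo sapiens) for cytotoxicity, read by MTT assay, with a stated time of 72 h; on this read-out lower numbers stand for stronger inhibition and higher numbers for weaker inhibition:
compound 1 `Cc1cc(=O)n(-c2ccccc2OC(F)(F)F)nc1C(=O)Nc1ccc(Oc2ncnc3[nH]ccc23)cc1` gives 16200 nM
compound 2 `Cc1cc(=O)n(-c2ccccc2OC(F)(F)F)nc1C(=O)Nc1ccc(Oc2ncnc3c2ccn3C)cc1` gives 25200 nM

Among the compounds with values here, compound 2 stands with the highest of the two numbers in this assay; the only step, a 1.6-fold higher number from compound 1 to compound 2 (0.19 log units; within the scatter), is within the scatter. Compound 3 `Cc1cc(=O)n(-c2cccc(F)c2)nc1C(=O)Nc1ccc(Oc2ncnc3c2ccn3C)cc1` differs from compound 2 by 3-fluorophenyl in place of 2-(trifluoromethoxy)phenyl on an aromatic nitrogen. Within the data shown here, no measured step touches this aryl group, so nothing in the data bears on it; the expected step of a 1.1-fold lower number from compound 2 to compound 3 (0.06 log units; within the scatter) is therefore set within the scatter, with a wide range. Compound 3 is estimated at 22000 nM in this assay, expected between 7000 nM and 70000 nM.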

Compound 3, half-maximal inhibitory concentration: 23400 nM
Compound 3: the middle estimate sits 1.1-fold (0.03 log units) below what was measured, and the stated range covers the measured number.
By their numbers in this assay, from the lowest: compounds 1, 3 and 2 (each within the scatter of the next).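

In this assay the aryl group on the aromatic nitrogen gets its first reading: 3-fluorophenyl in place of 2-(trifluoromethoxy)phenyl gives a 1.1-fold lower number from compound 2 to compound 3 (0.03 log units; within the scatter). The assay does not tell these two aryl groups apart, even though the entering group has fewer heavy atoms and no hydrogen-bond acceptor. No available evidence bears on this result. Still open, from the compounds shown here alone, is whether any group at this position moves the number beyond the scatter, such as a phenyl ring carrying an amine or a carboxylic acid. Going by these compounds, a longer chain in place of the methyl on the core's aromatic nitrogen is equally open.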